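The compounds below may be only part of what the source reports. "The series", "measured", "known", "first", "only" and "open" are said of these compounds alone.

Measured compounds:
compound 1 `Cc1cc(C(F)(F)F)cc(NC[C@@H]2CC3(CC3)CN2C(=O)c2nc(C)sc2-c2ccccc2)n1`: 8.6
compound 2 `Cc1ccc(-c2ncccn2)c(C(=O)N2CC3(CC3)C[C@H]2CNc2cc(C(F)(F)F)ccn2)c1`: 7.8
compound 3 `O=C(c1cc(Cl)ccc1-c1ncccn1)N1CC2(CC2)C[C@H]1CNc1ccc(C(F)(F)F)cn1`: 7.2

In a functional assay on HEK293 cells for antagonist activity at Orexin receptor type 2 (Homo sapiens), read by FLIPR and calcium flux (a higher number here means a more potent compound, by a factor of ten per unit of this negative logarithm, a lower number a less potent compound), compound 1 stands highest of the three; its lead over compound 2 and over compound 3 is beyond the usual scatter, so it counts as the most potent of this small set. Compound 4 `Cc1nc(C(=O)N2CC3(CC3)C[C@H]2CNc2ccc(Cl)cn2)c(-c2ccccc2)s1` keeps the core of compound 1 and changes only the group on the amine nitrogen: 5-chloropyridin-2-yl in place of 6-methyl-4-(trifluoromethyl)pyridin-2-yl on an amine nitrogen, a smaller pyridine ring carrying a chlorine instead of a methyl and a trifluoromethyl. Among the compounds with values here, no measured pair isolates this change, so a step is expected from the values of compounds 2 and 3, both lower than compound 1 with their own differently substituted pyridines: a loss in this assay beyond the scatter is expected, a number 0.80 log units lower from compound 1 to compound 4 (beyond the scatter). Compound 4 is estimated at 7.8, within 7.2 to 8.4.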

Compound 4, negative logarithm of the antagonist equilibrium constant: 7.1
The estimate for compound 4 lay 0.70 log units above the measured number; the whole stated range lies above it.
By their numbers in this assay, from the lowest: compounds 4 and 3 (each within the scatter of the next); then compound 2; then compound 1.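

Within this assay the group on the amine nitrogen proves to matter greatly: 5-chloropyridin-2-yl in place of 6-methyl-4-(trifluoromethyl)pyridin-2-yl gives a number 1.50 log units lower from compound 1 to compound 4 (beyond the scatter) with the rest of the molecule unchanged. Both groups are single pyridine rings, so a pyridine ring alone does not preserve the potency of compound 1. Nothing available here explains this loss.

The methyl, trifluoromethyl and chlorine changed together, so their separate contributions remain unresolved. Also open, going by these compounds, is how a pyridine ring carrying a nitrile or a methoxy group would compare at this position.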